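This account rests on a few compounds, and the source may have more. Where it says the series, first, only, none or still open, it means among the compounds named here.

Three compounds share one core and differ only in where the substituents sit on the phenyl ring that carries the long chain. Compound 1 `Cc1cc(OCCCCCCC[N+]23CCN(CC2)CC3)ccc1-n1cc(C(=O)Nc2cc(F)cc(F)c2)c(=O)c2ccc(N(C)C)nc21` gives "not active" (no number reported) in an assay on LX2 cells for inhibition of COL1A1 promoter (Homo sapiens), read by a luciferase reporter, with a stated time of 24 h, tested at 50 uM; a lower number here means a weaker effect, a higher number a stronger effect of the compound at the concentration tested. Compound 2 `Cc1cc(-n2cc(C(=O)Nc3cc(F)cc(F)c3)c(=O)c3ccc(N(C)C)nc32)ccc1OCCCCCCC[N+]12CCN(CC1)CC2` reaches 20.8% in this assay. Compound 3 `Cc1ccc(-n2cc(C(=O)Nc3cc(F)cc(F)c3)c(=O)c3ccc(N(C)C)nc32)cc1OCCCCCCC[N+]12CCN(CC1)CC2` gives 9.71% in this assay, the lowest of the two numbers shown, with compound 2 standing higher by a margin beyond the usual scatter, while compound 1 offers no number at all.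

Compound 4 `CN(C)c1ccc2c(=O)c(C(=O)Nc3cc(F)cc(F)c3)cn(-c3ccc(Cl)c(OCCCCCCC[N+]45CCN(CC4)CC5)c3)c2n1` keeps everything of compound 3 except one group: chloro in place of methyl on an aromatic carbon. Both the leaving and the entering group are single heavy atoms without donors, acceptors or charge, so the change is a small one. Within the data shown here, with no measured step of this type to lean on, the expected step from compound 3 to compound 4 in this assay is a number 1.3 percentage points higher from compound 3 to compound 4 (within the scatter), essentially none beyond the scatter. Compound 4 is therefore estimated to reach 11% in this assay, within a range of 0% to 26%.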

Compound 4, a percentage reported as inhibition, at one concentration (the size of the read-out at that concentration, not a potency): 18.7%
The estimate for compound 4 lay 7.7 percentage points below the measured number; the range from low to high includes it.
By their numbers in this assay, from the lowest: compounds 3, 4 and 2 (each within the scatter of the next, the first and the last beyond it).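

In this assay, chloro in place of methyl on this aromatic carbon, ortho to a large group and para to a large group, gives a number 9 percentage points higher from compound 3 to compound 4 (within the scatter). Among these compounds, this is the first measured step at this position, and it shows that, for this pair, the methyl can be exchanged for a chloro without a difference that stands clear of the scatter. Nothing measured here offers an explanation of this result.

As far as these compounds go, whether a methoxy group, a bromo group or an amine on the same carbon would move the read-out beyond the scatter remains open. Also open, from the compounds shown here alone, is whether chloro in place of methyl would give a similar step on compound 2, and each number describes the size of the effect at one concentration, so how the effects compare at other concentrations remains unknown.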